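The source may hold more compounds than are shown below. What is called first, only, known or untested is meant among the compounds shown, and "the series" means these compounds.

Compound 1 `Cc1ccc(/N=N/N(C)C)cc1` gives 3.76 in a functional assay on L1210 cells (Mus musculus) for antiproliferative activity (on this read-out lower numbers stand for lower potency and higher numbers for higher potency (the scale is a negative logarithm)), the higher of the two numbers measured. Among the compounds with values here, compound 2 `COC(=O)c1ccc(/N=N/N(C)C)cc1` gives 3.2, and the only measured step, a number 0.56 log units lower from compound 1 to compound 2 (beyond the scatter), concerns an exchange on an aromatic carbon. Compound 3 `CC(=O)N(C)/N=N/c1ccc(C)cc1` has not been measured; it differs from compound 1 by acetyl in place of methyl on an amine nitrogen. That change sits on the amine nitrogen, a different place from the measured step, so no shown step bears directly on it. A modest step, a number 0.36 log units lower from compound 1 to compound 3 (beyond the scatter), is expected, with wide uncertainty. Compound 3 is therefore estimated at 3.4, within 2.7 to 4.1.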

Compound 3, logarithm of the reciprocal of the active concentration, log(1/C): 2.78
Compound 3: the middle estimate sits 0.62 log units above what was measured, and the stated range covers the measured number.
By their numbers in this assay, from the lowest: compound 3; then compound 2; then compound 1.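

The amine nitrogen is a second place where a single exchange moves the number in this assay: acetyl in place of methyl there gives a number 0.98 log units lower from compound 1 to compound 3 (beyond the scatter). The exchange adds a carbonyl and a hydrogen-bond acceptor to the group on that nitrogen, and activity remains measurable, though lower. Nothing measured here explains the drop. The compounds shown leave open how an ethyl group or a longer chain on that nitrogen would compare, which could help separate the effect of added carbon from that of the carbonyl.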